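A few compounds are considered here, and "the series" means these few. Any claim that something is new, unique, unknown or untested is made for them only; others in the source may bear on it.

Measured compounds:
- compound 1, `CCCCOC(=O)C(=O)C(CC)NC(=O)C(CC(C)C)NC(=O)OCc1ccccc1` — 400 nM
- compound 2, `CCOC(=O)C(=O)C(CC)NC(=O)C(CC(C)C)NC(=O)CCCCc1ccccc1` — 1900 nM
- compound 3, `CCOC(=O)C(=O)[C@H](CC)NC(=O)[C@H](CC(C)C)NC(=O)[C@H](CC(C)C)NS(=O)(=O)c1ccc2ccccc2c1` — 1400 nM

In an assay on isolated protein (Oryctolagus cuniculus) for inhibition of Calpain-2 catalytic subunit (Homo sapiens), at pH 8.0 (a higher number here means a weaker inhibitor, a lower number a stronger inhibitor), compound 1 gives the lowest of the three numbers. Compound 3 stands nearest to it, with a higher number beyond the scatter, and compound 2 stands furthest, with a still higher number, also beyond the scatter. Compound 1 is therefore the strongest inhibitor among the measured ones.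

Compound 4, `CCCCCCCCCCNC(=O)C(=O)C(CC)NC(=O)C(CC(C)C)NC(=O)OCc1ccccc1`, has not yet been measured in this assay. It differs from compound 1 in one place: decylamino in place of butoxy on a carbonyl carbon. The change sits at the end of the molecule where the butyl ester of compound 1 is exchanged for a decylamide; the rest of the shared core is kept.

Going by the values given here, no measured pair shows this change, so the expected step rests on compound 1 alone, whose value in this assay is 400 nM. The expected step of a 2.0-fold lower number from compound 1 to compound 4 (0.30 log units; within the scatter) is small and points toward a stronger inhibitor, though it may well stay within the scatter. Compound 4 is thus estimated at 200 nM in this assay, with a range from 50 nM to 800 nM.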

Compound 4, inhibition constant: 600 nM
Compound 4: middle estimate off by 3.0-fold (0.48 log units), on the low side; the measured number falls inside the stated range.
By their numbers in this assay, from the lowest: compounds 1 and 4 (each within the scatter of the next); then compounds 3 and 2 (each within the scatter of the next).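

In this assay, decylamino in place of butoxy on a carbonyl carbon gives a 1.5-fold higher number from compound 1 to compound 4 (0.18 log units; within the scatter), so the two compounds cannot be told apart in this measurement, and this position accepts a far longer chain with no clear loss of inhibition. The exchange alters two things at once, the chain length and the atom joined to the carbonyl carbon, which is nitrogen carrying a hydrogen-bond donor instead of oxygen, so this single step cannot separate their contributions or show whether they offset each other. Nothing available explains why the values stay so close.

Butylamino would keep the chain of compound 1 while exchanging only oxygen for nitrogen, and decyloxy would keep the oxygen while lengthening the chain, so the two contributions remain unseparated. Also open, on these data alone, is how this position would respond to a carboxylic acid or an amine at the end of the chain.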